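The source may report more compounds than this note shows. Statements on the series, on what has been measured and on what is new or still open speak of the compounds shown alone.

Measured so far:
Compound 1, `O=C(/C=C/c1cccs1)c1cc(O)c(O)c([N+](=O)[O-])c1`, in an assay on isolated protein for inhibition of Amine oxidase [flavin-containing] B (Homo sapiens), read by fluorescence (a lower number here means a stronger inhibitor, a higher number a weaker inhibitor), compound 1 gives 62900 nM.
Compound 2, `CC(=O)N1N=C(c2cc(O)c(O)c([N+](=O)[O-])c2)CC1c1cccc(O)c1`, in this assay compound 2 gives 85200 nM.
Compound 3, `O=C(/C=C/c1ccsc1)c1cc(O)c(O)c([N+](=O)[O-])c1`, in this assay compound 3 gives 42100 nM.

Compound 3 carries the lowest of the three numbers in this assay. Its nearest neighbour is compound 1, whose value differs by a margin within the scatter, so no order between compound 3 and compound 1 can be claimed. Compound 2 is the furthest of the three, and that gap lies beyond the scatter.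

Among the compounds with values here, the only single-point step measured within the set is a 1.5-fold lower number from compound 1 to compound 3 (0.17 log units; within the scatter), which exchanges one five-membered heteroaryl ring for another on the same chain carbon and leaves the number essentially where it was.

Compound 4, `O=C(/C=C/c1ccoc1)c1cc(O)c(O)c([N+](=O)[O-])c1`, has not yet been measured. Relative to compound 3 the change is furan-3-yl in place of thiophen-3-yl on a double-bonded chain carbon bound to a double-bonded chain carbon. The step from compound 1 to compound 3 is the only one that bears on this kind of exchange, and it stayed within the scatter. On that basis the step of a 1.1-fold higher number from compound 3 to compound 4 (0.03 log units; within the scatter) is expected to be no larger than the scatter in either direction. Compound 4 is therefore estimated at 45000 nM in this assay, with a range from 18000 nM to 110000 nM.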

Compound 4, half-maximal inhibitory concentration: 71400 nM
The estimate for compound 4 lay 1.6-fold (0.20 log units) below the measured number; the range from low to high includes it.
By their numbers in this assay, from the lowest: compounds 3, 1, 4 and 2 (each within the scatter of the next, the first and the last beyond it).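

In this assay, within the data shown here, furan-3-yl in place of thiophen-3-yl on a double-bonded chain carbon bound to a double-bonded chain carbon gives a 1.7-fold higher number from compound 3 to compound 4 (0.23 log units; within the scatter) and furan-3-yl in place of thiophen-2-yl at that same place gives a 1.1-fold higher number from compound 1 to compound 4 (0.06 log units; within the scatter) so the exchange of ring sulfur for ring oxygen, which the earlier compounds did not cover, stays within the scatter from both thiophene rings. At this place compound 1, compound 3 and compound 4 therefore cannot be put in any order, and the change of hetero atom joins the change of ring attachment as a step with no readable effect on the number. Nothing at hand gives a reason for this flat result.

All three of these compounds carry a five-membered aromatic ring with one hetero atom at this place, so it remains open whether a phenyl ring, a pyridin-3-yl ring or an open alkyl chain there would move the number beyond the scatter. On these data alone, it also remains open whether an amine or a carboxylic acid on the furan-3-yl ring would do so.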